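A few compounds are considered here, and "the series" means these few. Any claim that something is new, unique, unknown or untested is made for them only; others in the source may bear on it.

Measured so far in a functional assay on HeLa cells (Homo sapiens) for inhibition, read by MTT assay, with a stated time of 72 h; on this read-out higher numbers stand for weaker inhibition and lower numbers for stronger inhibition:
- compound 1 `Clc1ccc(-c2nnc(SCCCN3CCN(c4nc5ccccc5o4)CC3)o2)cc1`: 101000 nM
- compound 2 `Fc1ccc(-c2nnc(SCCCN3CCN(c4nc5ccccc5o4)CC3)o2)cc1`: 196000 nM

Within the data shown here, compound 2 cannot be ranked against compound 1, the only other compound measured, since the two values lie within the scatter of each other. Among the measured compounds shown here, the single measured step, a 1.9-fold higher number from compound 1 to compound 2 (0.29 log units; within the scatter), is fluoro in place of chloro on an aromatic carbon, and it stays within the scatter.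

The next compound, compound 3 `Fc1ccc(-c2nnc(SCCCN3CCN(c4nc5ccccc5s4)CC3)o2)cc1`, keeps the fluoro of compound 2 and differs in one group: 1,3-benzothiazol-2-yl in place of 1,3-benzoxazol-2-yl on an amine nitrogen in a ring. In words, 1,3-benzothiazol-2-yl stands in place of 1,3-benzoxazol-2-yl on an amine nitrogen in a ring.

For the measured compounds named here, no measured step touches this group. The halogen step bears on it only indirectly, as a sign that one single change in this series has so far left the number within the scatter. The data give no direction, so no step beyond the scatter is expected in this assay. The expected change is small: a 1.3-fold lower number from compound 2 to compound 3 (0.12 log units; within the scatter).

For compound 3 the estimated value is 150000 nM, with an expected range of 60000 nM to 350000 nM.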

Compound 3, half-maximal inhibitory concentration: 134000 nM
For compound 3 the middle estimate is 1.1-fold (0.05 log units) above the measured one; measured number inside the range.
By their numbers in this assay, from the lowest: compounds 1, 3 and 2 (each within the scatter of the next).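

In this assay, among these compounds, 1,3-benzothiazol-2-yl in place of 1,3-benzoxazol-2-yl on an amine nitrogen in a ring gives a 1.5-fold lower number from compound 2 to compound 3 (0.17 log units; within the scatter), the first measured step at this position, and it lies within the scatter. The two groups have the same heavy-atom count and differ only in one ring atom, sulfur for oxygen, so this exchange at this position does not separate compound 2 from compound 3 on this read-out, and with the halogen step it makes two single-place steps in the series, both within the scatter. No available evidence bears on the reason for this result.

Still open, on these data alone, is whether a group of a different kind on this ring nitrogen, such as a plain phenyl or an acetyl, would give a step beyond the scatter, as the two groups compared here share the same ring make-up. Also open, as far as these compounds go, are whether a longer chain in place of the three-carbon chain would move the number, and whether the fluoro and chloro pair would read the same with 1,3-benzothiazol-2-yl in place.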